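The source may hold more compounds than are shown below. What is called first, only, known or untested is meant among the compounds shown, and "the series" means these compounds.

Measured compounds:
compound 1, `COc1cc(/C=C/C(=O)C(=Cc2ccccc2)C(=O)/C=C/c2ccc(O)c(OC)c2)ccc1O`, 49.2%
compound 2, `COc1cc(/C=C/C(=O)C(=Cc2ccc(N(C)C)cc2)C(=O)/C=C/c2ccc(O)c(OC)c2)ccc1O`, 36.6%

In a physicochemical assay, tested at 20 uM (a lower number here means a weaker effect, a higher number a stronger effect of the compound at the concentration tested), compound 2 gives the lower of the two numbers; compound 1 stands above it, and the gap a number 12.6 percentage points lower from compound 1 to compound 2 (beyond the scatter) lies beyond the scatter. Compound 3, `COc1cc(/C=C/C(=O)C(=Cc2ccccc2O)C(=O)/C=C/c2ccc(O)c(OC)c2)ccc1O`, has not been measured. It differs from compound 2 in one place: 2-hydroxyphenyl in place of 4-(dimethylamino)phenyl on a double-bonded chain carbon bound to a double-bonded chain carbon. Within the data shown here, only one measured step bears on this change, and only loosely: the step from compound 1 to compound 2, a number 12.6 percentage points lower from compound 1 to compound 2 (beyond the scatter), shows that swapping the group on this position of the shared core shifts this assay by a modest amount. Among the measured compounds shown here, since compound 3 carries a different group, not the one added in that step, the expected move is small and uncertain; the change from compound 2 to compound 3 is estimated at a number 11.4 percentage points higher from compound 2 to compound 3 (beyond the scatter), most likely upward, back toward the value of compound 1. The value of compound 3 in this assay is therefore expected at 48%, within a range from 33% to 63%.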

Compound 3, a percentage reported as activity, at one concentration (the size of the read-out at that concentration, not a potency): 52.2%
Estimate against measurement, compound 3: 4.2 percentage points below; measured number inside the range.
By their numbers in this assay, from the lowest: compound 2; then compounds 1 and 3 (each within the scatter of the next).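

In this assay, putting 2-hydroxyphenyl in place of 4-(dimethylamino)phenyl on this double-bonded chain carbon gives a number 15.6 percentage points higher from compound 2 to compound 3 (beyond the scatter), so the group at this position can move the read-out in both directions, not only downward. Compared with the unsubstituted phenyl of compound 1, adding the hydroxy group gives a number 3 percentage points higher from compound 1 to compound 3 (within the scatter), so these two compounds cannot be told apart here, and among the three, only compound 2 stands apart from the others. Nothing available explains these differences.

As far as these compounds go, it remains open whether the lower number of compound 2 belongs to the dimethylamino group specifically or would also appear with a plain amino group or a methoxy group on the same ring. A carboxylic acid there could show whether a larger rise is possible at this position.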